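Amide for ester on an anilino oxadiazole scaffold

The compounds below may be only part of what the source reports. "The series", "measured", "known", "first", "only" and "open" are said of these compounds alone.

Three compounds sharing one core were tested in an ADME assay on HeLa cells (Homo sapiens) for cytotoxicity, read by crystal violet staining, with a stated time of 72 h; on this read-out higher numbers stand for lower toxicity in this test and lower numbers for higher toxicity in this test. Compound 1 `CCOC(=O)c1cc(CCCOc2ccc(-c3noc(C(F)(F)F)n3)cc2C(F)(F)F)on1` gives 28400 nM in this assay. Compound 2 `CN(C)C(=O)c1cc(CCCOc2ccc(-c3noc(C(F)(F)F)n3)cc2C(F)(F)F)on1` gives 19200 nM in this assay. The difference between them is dimethylamino in place of ethoxy on a carbonyl carbon, and the step of a 1.5-fold lower number from compound 1 to compound 2 (0.17 log units; within the scatter) stays inside the usual scatter, so the two values cannot be told apart. Compound 3 `CCOC(=O)c1cc(CCCOc2ccc(-c3noc(C(F)(F)F)n3)cc2N)on1` differs from compound 1 by amino in place of trifluoromethyl on an aromatic carbon. For compound 3 this assay reports only a limit, > 100000 nM, not a number. The step of an at least 3.5-fold higher number from compound 1 to compound 3 (0.54 log units; beyond the scatter) is therefore at least modest, with the limit of > 100000 nM in this assay, at which 1 of the 3 values shown sits, marking where the value sits.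

Compound 4 `CN(C)C(=O)c1cc(CCCOc2ccc(-c3noc(C(F)(F)F)n3)cc2N)on1` is not yet measured. It differs from compound 3 by dimethylamino in place of ethoxy on a carbonyl carbon, the same change that separates compound 1 from compound 2; the two cores differ by amino in place of trifluoromethyl on an aromatic carbon. Because the earlier step of a 1.5-fold lower number from compound 1 to compound 2 (0.17 log units; within the scatter) was within the scatter, the step of a number no higher from compound 3 to compound 4 (the limit leaves the size open) is expected to be small as well. Compound 4 is thus estimated at 100000 nM in this assay, most likely again reported only as a limit, within a range of 50000 nM to 250000 nM.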

Compound 4, half-maximal cytotoxic concentration: 90800 nM
Compound 4: middle estimate off by 1.1-fold (0.04 log units), on the high side, and the stated range covers the measured number.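

For compound 3, > 100000 nM is a limit and not a number. The step of an at least 1.1-fold lower number from compound 3 to compound 4 (0.04 log units; that floor lies within the scatter) therefore fixes only a floor, and while this fits dimethylamino in place of ethoxy carrying over from the core of compound 1 to the core of compound 3, it does not prove that the change has the same size on both: the same change on two cores in this assay, a 1.5-fold lower number (0.17 log units; within the scatter) from compound 1 to compound 2 and an at least 1.1-fold lower number (0.04 log units; that floor lies within the scatter) from compound 3 to compound 4; the limit leaves it open whether they differ The other change, amino in place of trifluoromethyl, gives a 4.7-fold higher number from compound 2 to compound 4 (0.67 log units; beyond the scatter), so lower toxicity in this test appears with the dimethylamino group as well as with the ethoxy group, though how closely the two sizes match stays unsettled: the same change on two cores in this assay, an at least 3.5-fold higher number (0.54 log units; beyond the scatter) from compound 1 to compound 3 and a 4.7-fold higher number (0.67 log units; beyond the scatter) from compound 2 to compound 4; the limit leaves it open whether they differ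

The compounds shown leave open how other groups on the carbonyl carbon, such as a hydroxy group as in a carboxylic acid or a cyclic amine as in a morpholine amide, would read in this assay. They also leave open whether a group such as methoxy or a nitrile, in the place held by amino, would read like amino or like trifluoromethyl.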